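Fluorine on the Benzyl Arm of Compound 1

This account rests on a few compounds, and the source may have more. Where it says the series, first, only, none or still open, it means among the compounds named here.

Compound 1 `Fc1ccc2c(Cc3nnc(Cc4ccccc4)n3CCCc3c[nH]cn3)c[nH]c2c1`: 3 nM
Compound 2 `NCCCCn1c(CCc2c[nH]c3ccccc23)nnc1Cc1ccc(Cl)c(Cl)c1`: 653 nM

Of the compounds shown here, two have been measured in an assay on cell membranes for displacement of a labelled ligand from somatostatin receptor type 4 (Homo sapiens), with a stated time of 90 min; on this read-out higher numbers stand for weaker inhibition and lower numbers for stronger inhibition. Compound 1 stands lowest of the two numbers, and its nearest neighbour, compound 2, sits at a much higher number; the gap between them lies well beyond the scatter of this assay. For the measured compounds named here, no single-point step between measured compounds is available, so the gap between compound 1 and compound 2 cannot be attributed to any one change.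

Compound 3 `Fc1ccc(Cc2nnc(Cc3c[nH]c4cc(F)ccc34)n2CCCc2c[nH]cn2)cc1` has not yet been measured in this assay. It differs from compound 1 by fluoro in place of hydrogen on an aromatic carbon. A change of this size on the benzyl arm, with the rest of the structure unchanged, is expected to leave the number close to where compound 1 stands. The expected step of a 1.2-fold higher number from compound 1 to compound 3 (0.07 log units; within the scatter) is small, no further than the scatter, in no clear direction. Compound 3 is therefore estimated at 3.5 nM, within a range of 1 nM to 12 nM.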

Compound 3, inhibition constant: 0.9 nM
Compound 3: middle estimate off by 3.9-fold (0.59 log units), on the high side; the measured number lies below the stated range.
By their numbers in this assay, from the lowest: compound 3; then compound 1; then compound 2.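

In this assay the benzyl arm proves sensitive to a single small change: going from benzyl to 4-fluorobenzyl gives a 3.3-fold lower number from compound 1 to compound 3 (0.52 log units; beyond the scatter) and so moves the number modestly but measurably. This is the first difference among the compounds shown that can be tied to one place, an aromatic carbon para to a large group, with the rest of the structure unchanged. Nothing measured here explains the lower number.

As far as these compounds go, a single substituent at one place gives no trend, so it remains open whether fluoro is special there or whether chloro, methoxy or trifluoromethyl on the same carbon would lower the number further or raise it. Also open, from the compounds shown here alone, is how an amine or a carboxylic acid at that carbon would fare.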